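Replacing the methoxyphenyl arm: an expected cytotoxicity value

This account rests on a few compounds, and the source may have more. Where it says the series, first, only, none or still open, it means among the compounds named here.

Measured in a functional assay on HeLa cells (Homo sapiens) for cytotoxicity, read by MTT assay, with a stated time of 2 days, tested at 0.1 uM; on this read-out higher numbers stand for a weaker effect at the one concentration tested and lower numbers for a stronger effect:
Compound 1 `COc1ccc(-c2cc(C(C)=O)c3[nH]c(-c4ccccc4)cc3c2)cc1` gives 87.9%
Compound 2 `COc1ccc(-c2cc(C(C)=O)c3[nH]c(-c4ccc(F)cc4)cc3c2)cc1` gives 74.5%
Compound 3 `COc1ccc(-c2cc(C(C)=O)c3[nH]c(-c4ccc(OC)cc4)cc3c2)cc1` gives 74.5%

Compound 3 matches compound 2, since no change at the digits printed from compound 2 to compound 3 (within the scatter), while compound 1 sits apart, as a number 13.4 percentage points lower from compound 1 to compound 3 (beyond the scatter) shows. Compound 4 `COc1ccc(-c2cc3cc(/C=C/c4ccc(F)cc4)cc(C(C)=O)c3[nH]2)cc1` differs from compound 3 by 2-(4-fluorophenyl)ethenyl in place of 4-methoxyphenyl on an aromatic carbon. The measured steps, a number 13.4 percentage points lower from compound 1 to compound 2 (beyond the scatter) and a number 13.4 percentage points lower from compound 1 to compound 3 (beyond the scatter), changed only the ring carrying the amide hydrogen's neighbour group, not the position altered here, so they give no direct guide; the change here is larger. Among the measured compounds shown here, with no closer precedent, the expected step is a number 3.5 percentage points higher from compound 3 to compound 4 (within the scatter), a modest shift within the scatter, with wide uncertainty. Compound 4 is therefore expected at 78%, estimated between 55% and 95% in this assay.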

Compound 4, a percentage reported as activity, at one concentration (the size of the read-out at that concentration, not a potency): 90.5%
The estimate for compound 4 lay 12.5 percentage points below the measured number; measured number inside the range.
By their numbers in this assay, from the lowest: compounds 2 and 3 (each within the scatter of the next); then compounds 1 and 4 (each within the scatter of the next).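

In this assay, putting 2-(4-fluorophenyl)ethenyl in place of 4-methoxyphenyl gives a number 16 percentage points higher from compound 3 to compound 4 (beyond the scatter), which here means a weaker effect at the one concentration tested. The earlier steps shown here altered only a substituent on a phenyl ring and lowered the number, whereas replacing this whole group on the carbon meta to the acetyl group raises it. No measurement bears on why the number rose.

The compounds shown leave open whether the double bond or the fluoro group matters more. On these data alone, how an amine or a carboxylic acid at this carbon would read also remains open.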